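From 2,4-difluorophenyl to pyridin-2-yl: a small step expected

This account rests on a few compounds, and the source may have more. Where it says the series, first, only, none or still open, it means among the compounds named here.

Of the compounds shown here, three sharing one core have been measured in a functional assay on HeLa cells (Homo sapiens) for antiproliferative activity, read by MTT assay, with a stated time of 72 h (on this read-out lower numbers stand for stronger inhibition and higher numbers for weaker inhibition), and they differ only in the aromatic group on an amine nitrogen in a ring. Compound 1 `Nc1nc(N)c2cc(CSC(=S)N3CCN(c4ccc(O)cc4)CC3)ccc2n1`, with 4-hydroxyphenyl, gives 5180 nM. Compound 2 `Cc1ccc(N2CCN(C(=S)SCc3ccc4nc(N)nc(N)c4c3)CC2)c(C)c1`, with 2,4-dimethylphenyl, gives 3190 nM. Compound 3 `Nc1nc(N)c2cc(CSC(=S)N3CCN(c4ccc(F)cc4F)CC3)ccc2n1`, with 2,4-difluorophenyl, gives 3800 nM.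

Compound 3 is not truly separated from either of the others: the data show a 1.2-fold higher number from compound 2 to compound 3 (0.08 log units; within the scatter) and a 1.4-fold lower number from compound 1 to compound 3 (0.13 log units; within the scatter). Compound 4 `Nc1nc(N)c2cc(CSC(=S)N3CCN(c4ccccn4)CC3)ccc2n1` has not yet been measured. It carries pyridin-2-yl in place of 2,4-difluorophenyl on an amine nitrogen in a ring.

Within the data shown here, no measured compound has a ring with a hetero atom at this place, so the exact swap is untested. The nearest evidence is the set of other swaps at the same place, which includes a 1.6-fold lower number from compound 1 to compound 2 (0.21 log units; within the scatter). All three stayed small, though three compounds are a thin basis. In this assay, no step beyond the scatter is therefore expected, with an estimated 1.1-fold higher number from compound 3 to compound 4 (0.02 log units; within the scatter). For compound 4 the expected value is 4000 nM, with an estimated range from 1900 nM to 9000 nM.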

Compound 4, half-maximal inhibitory concentration: 5090 nM
Compound 4: middle estimate off by 1.3-fold (0.10 log units), on the low side, within the range that was stated.
By their numbers in this assay, from the lowest: compounds 2, 3, 4 and 1 (each within the scatter of the next).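

Pyridin-2-yl is the first group at this place with a hetero atom in its aromatic ring, and it also lacks the fluorine atoms of 2,4-difluorophenyl. Even so, in this assay the new compound is not truly separated from any earlier one (a 1.3-fold higher number from compound 3 to compound 4 (0.13 log units; within the scatter)), (a 1.6-fold higher number from compound 2 to compound 4 (0.20 log units; within the scatter)) and (a 1.0-fold lower number from compound 1 to compound 4 (0.01 log units; within the scatter)). All four compounds now lie within the scatter of one another, so replacing a carbon atom of the aromatic ring with nitrogen, like the earlier changes to the groups on that ring, gives no measurable separation here, though nothing shown explains this closeness.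

Every group shown is a six-membered aromatic ring attached directly to the amine nitrogen, so it remains open whether a benzyl, cyclohexyl or simple methyl group would stay in the same range. Among these compounds, it is also open whether pyridin-3-yl or pyridin-4-yl would match pyridin-2-yl, and whether a carboxylic acid or an aminomethyl group on the aromatic ring would produce a first step beyond the scatter.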